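Swapping the aryl arm on a quinazoline thiazolidinone series

The compounds below may be only part of what the source reports. "The series", "measured", "known", "first", "only" and "open" are said of these compounds alone.

Compound 1 `COc1ccc(/C=C2/SC(N3CCC[C@H]3C(=O)Nc3ccc4ncnc(Nc5cccc(Cl)c5)c4c3)=NC2=O)cc1`: in a functional assay on HepG2 cells (Homo sapiens) for antiproliferative activity, read by MTT assay (on this read-out lower numbers stand for stronger inhibition and higher numbers for weaker inhibition), compound 1 gives 19000 nM.
Compound 2 `Cc1cccc(/C=C2/SC(N3CCC[C@H]3C(=O)Nc3ccc4ncnc(Nc5cccc(Cl)c5)c4c3)=NC2=O)n1`: in this assay compound 2 gives 4500 nM.
Compound 3 `O=C1N=C(N2CCC[C@H]2C(=O)Nc2ccc3ncnc(Nc4cccc(Cl)c4)c3c2)S/C1=C/c1ccc(-c2ccccc2)cc1`: in this assay compound 3 gives 15400 nM.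

Compound 3 sits second highest of the three numbers, close to compound 1 and well away from compound 2, which gives the lowest number. The new compound 4 `O=C1N=C(N2CCC[C@H]2C(=O)Nc2ccc3ncnc(Nc4cccc(Cl)c4)c3c2)S/C1=C/c1cccnc1Cl` differs from compound 3 in one place: 2-chloropyridin-3-yl in place of 4-phenylphenyl on a double-bonded chain carbon bound to a double-bonded ring carbon. For the measured compounds named here, two measured steps bear on this. The step of a 4.2-fold lower number from compound 1 to compound 2 (0.63 log units; beyond the scatter) shows that bringing a pyridine-type ring onto this chain carbon lowered the number, and the step of a 3.4-fold higher number from compound 2 to compound 3 (0.53 log units; beyond the scatter) shows that replacing that pyridine by 4-phenylphenyl raised it again. Since compound 4 again carries a pyridine-type ring, though with a different substitution than compound 2, a modest move toward a lower number is expected, with a 2.2-fold lower number from compound 3 to compound 4 (0.34 log units; beyond the scatter) as the estimated step. For compound 4 the expected value in this assay is 7000 nM, with a likely range from 2500 nM to 20000 nM.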

Compound 4, half-maximal inhibitory concentration: 6400 nM
Beside the measured number, compound 4's estimate is 1.1-fold (0.04 log units) above it; the measured number falls inside the stated range.
By their numbers in this assay, from the lowest: compounds 2 and 4 (each within the scatter of the next); then compounds 3 and 1 (each within the scatter of the next).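

With compound 4, a second pyridine-type ring joins the series, and in this assay it falls clear of both all-carbon aryl arms: a 2.4-fold lower number from compound 3 to compound 4 (0.38 log units; beyond the scatter) and a 3.0-fold lower number from compound 1 to compound 4 (0.47 log units; beyond the scatter) are both beyond the scatter. Compound 2 and compound 4 cannot be told apart (a 1.4-fold higher number from compound 2 to compound 4 (0.15 log units; within the scatter)), even though their rings differ in substituent and in the ring atom attached to the chain, so among these four compounds both pyridine-bearing arms give lower numbers than both all-carbon arms, with no exception. Nothing available explains this split.

Going by these compounds, it remains open whether the ring nitrogen alone goes with the lower numbers or the chlorine and methyl groups also play a part, which an unsubstituted pyridin-3-yl arm could help to separate. Also open, on these data alone, is how an aryl arm carrying an amine or a carboxylic acid would behave at this carbon.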